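The compounds below may be only part of what the source reports. "The series", "measured", "known", "first", "only" and "open" are said of these compounds alone.

Measured compounds:
compound 1, `COc1cc(Oc2cccc(Nc3ccccc3)c2)cc(OC)c1CNCc1ccc(F)cc1`: 2750 nM in a functional assay on HT-29 cells (Homo sapiens) for inhibition, read by MTT assay, with a stated time of 72 h; on this read-out lower numbers stand for stronger inhibition and higher numbers for weaker inhibition
compound 2, `COc1cc(Oc2cccc(Nc3ccccc3)c2)cc(OC)c1CN[C@H](C)c1ccccc1`: 5120 nM in this assay
compound 3, `COc1cc(Oc2cccc(Nc3ccccc3)c2)cc(OC)c1CNCc1ccc(O)cc1`: 2180 nM in this assay

Compound 3 gives the lowest of the three numbers in this assay, yet its nearest neighbour, compound 1, sits within the scatter of it, as the step of a 1.3-fold lower number from compound 1 to compound 3 (0.10 log units; within the scatter) shows, so these two cannot be ranked against each other; only compound 2 stands apart, seen in the step of a 2.3-fold lower number from compound 2 to compound 3 (0.37 log units; beyond the scatter). Compound 4, `COc1cc(Oc2cccc(Nc3ccccc3)c2)cc(OC)c1CNCc1ccc(Br)cc1`, has not yet been measured. It differs from compound 3 in one place: bromo in place of hydroxy on an aromatic carbon. The step that bears most directly on this change is a 1.3-fold lower number from compound 1 to compound 3 (0.10 log units; within the scatter), an exchange on the same aromatic carbon that stayed within the scatter. The step of a 1.9-fold higher number from compound 1 to compound 2 (0.27 log units; within the scatter), a change at the amine nitrogen, also stayed within the scatter. Going by the values given here, nothing among the measured compounds suggests that an exchange on this carbon moves the number far, so compound 4 is expected to land near compound 3, with a 1.1-fold higher number from compound 3 to compound 4 (0.06 log units; within the scatter) as the expected step. The estimate for compound 4 in this assay is 2500 nM, expected to fall between 1200 nM and 5500 nM.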

Compound 4, half-maximal inhibitory concentration: 3060 nM
Compound 4: middle estimate off by 1.2-fold (0.09 log units), on the low side, within the range that was stated.
By their numbers in this assay, from the lowest: compounds 3, 1, 4 and 2 (each within the scatter of the next, the first and the last beyond it).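

In this assay, bromo in place of hydroxy on this aromatic carbon, para to a large group, gives a 1.4-fold higher number from compound 3 to compound 4 (0.15 log units; within the scatter), and bromo in place of fluoro gives a 1.1-fold higher number from compound 1 to compound 4 (0.05 log units; within the scatter), so hydroxy, fluoro and bromo cannot be ranked at this position, even though bromo has neither the hydrogen-bond donor nor the hydrogen-bond acceptor counted for hydroxy. Going by these compounds alone, with 4-bromobenzyl in place of 1-phenylethyl on the amine nitrogen, the result is a 1.7-fold lower number from compound 2 to compound 4 (0.22 log units; within the scatter), whereas a 2.3-fold lower number from compound 2 to compound 3 (0.37 log units; beyond the scatter) is the only step in the set that goes beyond the scatter, so the separation of compound 2 rests on that single pair. No measurement shown here offers an explanation for these numbers. From the compounds shown here alone, it remains open whether a carboxylic acid or an amine on this carbon would move the number beyond the scatter. It also remains open whether the unsubstituted benzyl group would stay within the scatter of these compounds.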